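This account rests on a few compounds, and the source may have more. Where it says the series, first, only, none or still open, it means among the compounds named here.

Of the compounds shown here, two sharing one core have numbers so far. In an ADME assay on SH-SY5Y cells (Homo sapiens) for cytotoxicity, read by MTT assay, with a stated time of 72 h (a higher number here means a weaker inhibitor, a lower number a stronger inhibitor), compound 1 `O=C(CN1CCN(C(=O)c2ccc(Cl)cc2)CC1)N1CCN(CCCc2c[nH]c3ccc(F)cc23)CC1`, which carries 4-chlorophenyl on a carbonyl carbon, gives 125000 nM. Compound 2 `O=C(CN1CCN(C(=O)c2cccc(F)c2)CC1)N1CCN(CCCc2c[nH]c3ccc(F)cc23)CC1`, with 3-fluorophenyl there, gives 169000 nM. Going by the values given here, the only measured step, a 1.4-fold higher number from compound 1 to compound 2 (0.13 log units; within the scatter), lies within the scatter, so compound 2 stands level with compound 1 and the two numbers cannot be told apart.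

Compound 3 `O=C(CN1CCN(C(=O)c2ccccc2Br)CC1)N1CCN(CCCc2c[nH]c3ccc(F)cc23)CC1` keeps the core of compound 2 and alters a single group: 2-bromophenyl in place of 3-fluorophenyl on a carbonyl carbon. In words, it has 2-bromophenyl in place of 3-fluorophenyl on a carbonyl carbon. Among the compounds with values here, no measured compound carries 2-bromophenyl, so the evidence is indirect. Within the data shown here, the one step that bears on this change is also an exchange of one substituted phenyl for another on a carbonyl carbon, and a 1.4-fold higher number from compound 1 to compound 2 (0.13 log units; within the scatter) stayed within the scatter. On that single step, no change beyond the scatter is expected in this assay, in either direction. The expected step is a 1.3-fold lower number from compound 2 to compound 3 (0.10 log units; within the scatter). For compound 3 the estimated value is 135000 nM, with an expected range of 70000 nM to 260000 nM.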

Compound 3, half-maximal inhibitory concentration: 79100 nM
For compound 3 the middle estimate is 1.7-fold (0.23 log units) above the measured one; measured number inside the range.
By their numbers in this assay, from the lowest: compounds 3, 1 and 2 (each within the scatter of the next, the first and the last beyond it).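

In this assay, the position on a carbonyl carbon whose other neighbours are an amide-type nitrogen in a ring now gives a step beyond the scatter, though only a modest one (a 2.1-fold lower number from compound 2 to compound 3 (0.33 log units; beyond the scatter)), which the earlier exchange did not do. Going by these compounds alone, the same 2-bromophenyl group gives a step that stays within the scatter when it replaces 4-chlorophenyl (a 1.6-fold lower number from compound 1 to compound 3 (0.20 log units; within the scatter)), so compound 3 cannot be told apart from compound 1, and only the pair compound 2 and compound 3 is separated at this position, with compound 1 level with each of them. Nothing among the available data accounts for why one exchange clears the scatter and the other does not.

In the step to compound 3, the halogen and its place on the ring change together, so the compounds shown cannot say which of the two matters; 2-fluorophenyl or 3-bromophenyl would separate them. They also leave open whether a plain phenyl, a cyclohexyl, or a phenyl carrying an amine or a carboxylic acid would move the number further at this position, and whether the step holds on any other core.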